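This account rests on a few compounds, and the source may have more. Where it says the series, first, only, none or still open, it means among the compounds named here.

Measured so far:
Compound 1, `Cc1cc(NC(=O)Nc2ccc(C)c(Cl)c2)c2ccccc2n1`, gives 262 10^-6 cm/s.
Compound 2, `Cc1cc(NC(=O)Nc2ncccc2C)c2ccccc2n1`, gives 369 10^-6 cm/s.
Compound 3, `Cc1cc(NC(=O)Nc2ccc(N)cc2)c2ccccc2n1`, gives 530 10^-6 cm/s.

All three share the same core and carry a urea linking it to a second aromatic ring; they were tested in an ADME assay for permeability, using PAMPA, at pH 7.4; on this read-out lower numbers stand for lower permeability and higher numbers for higher permeability. On the numbers shown, compound 3 has the highest value; compound 2 is nearest to it, and the gap from compound 2 to compound 3 is a 1.4-fold higher number from compound 2 to compound 3 (0.16 log units; within the scatter), so the two are not separated by this assay. Compound 1 stands furthest away, with the lower number of that pair.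

The next compound, compound 4, is `Cc1cc(NC(=O)Nc2cccc(Cl)c2)c2ccccc2n1`. It differs from compound 3 in one place: 3-chlorophenyl in place of 4-aminophenyl on an amide-type nitrogen. Going by the values given here, no measured step makes exactly this change. Among the compounds with values here, the only step available, a 1.4-fold higher number from compound 2 to compound 3 (0.16 log units; within the scatter), brings the 4-aminophenyl in from a different ring and stays within the scatter, which gives little guidance. Within the data shown here, compound 1, the only compound carrying a chlorine on that ring, has the lowest number of the three, but it also differs from compound 4 in a second place. For compound 4 a somewhat lower number than compound 3 is therefore expected, though a step of a 1.8-fold lower number from compound 3 to compound 4 (0.25 log units; within the scatter) would still lie within the scatter. The estimate for compound 4 is 300 10^-6 cm/s, in a range from 170 10^-6 cm/s to 520 10^-6 cm/s.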

Compound 4, apparent permeability: 566 10^-6 cm/s
For compound 4 the middle estimate is 1.9-fold (0.28 log units) below the measured one; measured number outside the range, above it.
By their numbers in this assay, from the lowest: compounds 1, 2, 3 and 4 (each within the scatter of the next, the first and the last beyond it).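

In this assay, the step to 3-chlorophenyl from 4-aminophenyl on the amide-type nitrogen is a 1.1-fold higher number from compound 3 to compound 4 (0.03 log units; within the scatter), and the step to it from 3-methylpyridin-2-yl is a 1.5-fold higher number from compound 2 to compound 4 (0.19 log units; within the scatter), so this position accepts all three rings without the assay separating them, even though the hydrogen-bond donor and acceptor counted on 4-aminophenyl are gone in 3-chlorophenyl. Going by these compounds alone, the one step here that clears the scatter is modest: a 2.2-fold higher number from compound 1 to compound 4 (0.33 log units; beyond the scatter), with hydrogen in place of methyl on an aromatic carbon, so the chlorine-bearing ring does not by itself go with the low number of compound 1, since compound 4 carries a chlorine too and still reaches the top group. No measurement at hand explains why these numbers fall as they do.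

As far as these compounds go, the methyl comparison rests on a single pair, so it remains unknown whether removing that methyl would matter in the same way on the other rings. From the compounds shown here alone, it is also open whether a ring bearing a carboxylic acid, a dimethylamino group or a longer chain such as propyl would stay in this same range in this assay.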